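A few compounds are considered here, and "the series" means these few. Any claim that something is new, unique, unknown or untested is made for them only; others in the source may bear on it.

Working notes on the series.

Three compounds of the shared core have numbers in a functional assay on the whole organism (blood) with Rattus norvegicus as the target, with stated times of 24 h and 1 h, at a dose of 1 mg/kg by the intraperitoneal route; on this read-out lower numbers stand for a weaker effect and higher numbers for a stronger effect at the one dose given. Compound 1 `COc1ccc(Cl)cc1C(=O)NCCC1CCN(S(=O)(=O)NC(=O)NC[C@@H]2C[C@@H]3C=C[C@@H]2C3)CC1` gives 27%. Compound 2 `O=C(NC1CCCCC1)NS(=O)(=O)N1CCC(CCNC(=O)c2cccc3cccnc23)CC1` gives 29%, and compound 3 `O=C(NC1CCCCC1)NS(=O)(=O)N1CCC(CCNC(=O)c2cc(Cl)cc3cccnc23)CC1` gives 17%. Compound 1 stands second of the three; its number lies within the scatter of compound 2 and also within the scatter of compound 3, so no order among the three can be drawn. Going by the values given here, the only one-place step measured so far is a number 12 percentage points lower from compound 2 to compound 3 (beyond the scatter), a modest fall beyond the scatter.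

Compound 4 `Cn1cc(C(=O)NCCC2CCN(S(=O)(=O)NC(=O)NC[C@@H]3C[C@@H]4C=C[C@@H]3C4)CC2)c(=O)n(C)c1=O` has not been measured. It differs from compound 1 in one place: a group of 10 heavy atoms (6 carbon, 2 nitrogen, 2 oxygen; one six-membered aromatic ring with 2 hetero atoms) in place of a group of 9 heavy atoms (7 carbon, 1 oxygen, 1 chlorine; one six-membered aromatic ring of carbon only), on a carbonyl carbon. Among the compounds with values here, the measured step concerns a chloro put on an aromatic carbon in a different part of the core and does not bear directly on this exchange of one aromatic group for another; the data hold no step of the kind made here. With nothing to point in either direction, the expectation for this assay is no step beyond the scatter, a number 2 percentage points lower from compound 1 to compound 4 (within the scatter), with wide uncertainty.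

Compound 4 is therefore estimated at 25% in this assay, within a range from 8% to 42%.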

Compound 4, a percentage reported as activity, at one dose (the size of the read-out at that dose, not a potency): 12%
Compound 4: middle estimate off by 13 percentage points, on the high side; low and high end bracket the measured number.
By their numbers in this assay, from the lowest: compounds 4, 3, 1 and 2 (each within the scatter of the next, the first and the last beyond it).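

At the carbonyl carbon whose other neighbour is the amide-type nitrogen, the choice of aromatic group registers in this assay: exchanging 5-chloro-2-methoxyphenyl for the group with a six-membered aromatic ring with 2 hetero atoms gives a number 15 percentage points lower from compound 1 to compound 4 (beyond the scatter). Going by these compounds alone, the earlier step showed only a chloro in place of hydrogen on an aromatic carbon, whereas this is the first measured exchange of a whole aromatic group at this place, and the read-out follows it beyond the scatter. The exchange changes several counted features at once, from 1 hydrogen-bond acceptor to 4 and from none to 2 double bonds outside aromatic rings, and nothing measured here connects the fall to any one of them or to the loss of the chloro or the methoxy.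

A plain phenyl group, or a phenyl group carrying only the chloro or only the methoxy, would help separate these contributions, while a carboxylic acid on the ring would test a quite different kind of group at this place. On these data alone, whether the same exchange gives a step of similar direction on the core of compound 2 remains open.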